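Cyano to Carbamoyl: What to Expect for Compound 3

The source may report more compounds than this note shows. Statements on the series, on what has been measured and on what is new or still open speak of the compounds shown alone.

Compound 1 `CCCNC(=O)c1oc2c(C(N)=O)c(OC)cc(OC)c2c1C` — in a functional assay on A549 cells (Homo sapiens) for cytotoxicity, read by MTT assay (on this read-out lower numbers stand for stronger inhibition and higher numbers for weaker inhibition), compound 1 reaches only a limit of the assay, > 93600 nM.
Compound 2 `COc1cc(OC)c2c(C)c(C=O)oc2c1C#N` — in this assay compound 2 is reported as "not active" (no number reported).

Among the measured compounds shown here, compound 2 therefore has no single number to stand on; the only other value shown is the limit of > 93600 nM in this assay, at which 1 of the 2 values shown sits, which is a limit rather than a measurement. Compound 3 `COc1cc(OC)c2c(C)c(C=O)oc2c1C(N)=O` differs from compound 2 by carbamoyl in place of cyano on an aromatic carbon. For the measured compounds named here, with no measured step to lean on, the expected change in this assay is none beyond the usual scatter, and a limit rather than a number is the likely outcome. For compound 3 the estimate is 100000 nM, expected to fall between 30000 nM and 500000 nM.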

Compound 3, half-maximal inhibitory concentration: 63800 nM
Compound 3: middle estimate off by 1.6-fold (0.20 log units), on the high side, and the stated range covers the measured number.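

In this assay compound 3, with carbamoyl on this aromatic carbon, gives 63800 nM as a true number, which neither earlier compound does. Compound 1 gives only a limit, not a number: the limit of > 93600 nM in this assay, at which 1 of the 3 values shown sits. Hydrogen in place of propylamino on the carbonyl carbon gives an at least 1.4-fold lower number from compound 1 to compound 3 (0.16 log units; that floor lies within the scatter) so this change is not shown to matter, and the step from cyano to carbamoyl cannot be read, as compound 2 has no number.

From the compounds shown here alone, whether an amine or a carboxylic acid on this aromatic carbon would give a clearly lower number remains open.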